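The source may hold more compounds than are shown below. What is called first, only, known or untested is meant among the compounds shown, and "the series" means these compounds.

Measured compounds:
compound 1, `COc1ccc(-c2cc(/C=C/C(=O)c3ccc(N)cc3)[nH]n2)cc1`: -91%
compound 2, `COc1ccc(C(=O)/C=C/c2cc(-c3cc(OC)c(OC)c(OC)c3)n[nH]2)cc1OC`: -99%

In a functional assay on TK-10 cells (Homo sapiens) for cytotoxicity, read by sulforhodamine B assay, with a stated time of 48 h, tested at 100 uM (on this read-out lower numbers stand for a stronger effect and higher numbers for a weaker effect at the one concentration tested), compound 1 gives -91%, and compound 2 gives -99%. Compound 1 sits at one end of the two numbers shown, but the gap to compound 2 lies within the usual scatter, so the two compounds cannot be told apart on this read-out. Compound 3, `COc1ccc(-c2cc(/C=C/C(=O)c3ccc(N)cc3)[nH]n2)cc1OC`, is the unmeasured analogue of compound 1; it differs by methoxy in place of hydrogen on an aromatic carbon. For the measured compounds named here, no pair of measured compounds differs in a single place, so there is no measured step to lean on for this change. Since compound 1 and compound 2 both give strongly negative numbers, the added methoxy group is expected to leave the read-out of compound 3 essentially where compound 1 stands, with a number 2 percentage points lower from compound 1 to compound 3 (within the scatter) expected to remain within the scatter. Compound 3 is therefore estimated at -93%, within a range of -100% to -75%.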

Compound 3, a percentage reported as activity, at one concentration (the size of the read-out at that concentration, not a potency): -98%
For compound 3 the middle estimate is 5 percentage points above the measured one; measured number inside the range.
By their numbers in this assay, from the lowest: compounds 2, 3 and 1 (each within the scatter of the next).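

The only single-place comparison among the compounds shown is methoxy in place of hydrogen on an aromatic carbon, ortho to a methoxy group and meta to a large group, and in this assay it gives a number 7 percentage points lower from compound 1 to compound 3 (within the scatter). This position therefore accepts the methoxy group without a change that can be told apart from the usual scatter of this read-out, although that holds only at the one concentration tested. No measured information bears on why the read-out behaves this way.

As far as these compounds go, whether a hydroxyl, a carboxylic acid or a longer alkoxy chain such as butoxy at this same position would shift the number stays open. The compounds shown also leave open whether compound 1 and compound 3 would separate at lower concentrations, since a single-concentration read-out is not a potency.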